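The compounds below may be only part of what the source reports. "The series", "measured", "known", "first", "only" and "open" are said of these compounds alone.

Series in a functional assay on Hs-578T cells (Homo sapiens) for antiproliferative activity; on this read-out lower numbers stand for stronger inhibition of growth and higher numbers for weaker inhibition of growth:
- Compound 1 `CCCCCCCCC(O)CCCCCC/C=C1\CC(CO)(COC(=O)C(C)(C)C)OC1=O`: > 10 ug/mL, a limit.
- Compound 2 `CC(C)(C)C(=O)OCC1(CO)C/C(=C\CCCCCCCCCCCO)C(=O)O1`: > 10 ug/mL, a limit.

Compound 2 has no number, only a limit, and it shares this position with compound 1: the limit of > 10 ug/mL in this assay, at which 2 of the 2 values shown sit.

Compound 3 `CC(C)(C)C(=O)OCC1(CO)C/C(=C\CCCCCCCCCCCCCCC=O)C(=O)O1` follows from compound 2 by 3-formylpropyl in place of hydroxy on a saturated chain carbon, ten or more bonds along the chain from a double-bonded chain carbon. In words, this is 3-formylpropyl in place of hydroxy on a saturated chain carbon, ten or more bonds along the chain from a double-bonded chain carbon.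

Within the data shown here, the only measured step that bears on this change is a step that the two limits leave unreadable from compound 1 to compound 2. It offers no size to carry over.

Given (the limit of > 10 ug/mL in this assay, at which 2 of the 2 values shown sit), no step beyond the scatter is expected in this assay, and no direction can be assigned. The expected step is a step that the limit leaves unreadable from compound 2 to compound 3. Another report of only a limit is the likeliest outcome. For compound 3 the estimated value is 14 ug/mL, with an expected range of 5 ug/mL to 40 ug/mL.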

Compound 3, concentration for 50% growth inhibition: > 10 ug/mL
Compound 3 ended at the assay's limit; the forecaster's own chance of this, stated with the estimate: 75%; the middle value is on the limit's open side.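

The steps to compound 3 from compound 1 and from compound 2 cannot be read in this assay, because all three compounds share one limit: the limit of > 10 ug/mL in this assay, at which 3 of the 3 values shown sit.

The compounds shown leave open how strongly any of them inhibits growth, and whether any of these chain changes shifts that read-out.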